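A few compounds are considered here, and "the series" means these few. Any claim that something is new, unique, unknown or untested is made for them only; others in the source may bear on it.

Measured in a functional assay on HeLa cells (Homo sapiens) for antiproliferative activity, read by sulforhodamine B assay; a higher number here means a weaker inhibitor of growth, a lower number a stronger inhibitor of growth:
- compound 1 `O[C@H]1CO[C@H](COCc2ccccc2)[C@@H](OCc2ccccc2)[C@@H]1OCc1ccccc1`: > 50000 nM (a limit of the assay)
- compound 2 `CCC[C@H]1O[C@H](COCc2ccccc2)[C@@H](OCc2ccccc2)[C@H](OCc2ccccc2)[C@H]1O`: 17400 nM

Compound 1 stands at a limit and not at a number, the only such case among the measured pair: the limit of > 50000 nM in this assay, at which 1 of the 2 values shown sits. Compound 3 `CCCC[C@@H]1O[C@H](COCc2ccccc2)[C@@H](OCc2ccccc2)[C@H](OCc2ccccc2)[C@H]1O` has not yet been measured. Its change from compound 1 is butyl in place of hydrogen on a saturated ring carbon, next to the ring oxygen: butyl in place of hydrogen on a saturated ring carbon.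

Within the data shown here, one measured step bears on this change, propyl in place of hydrogen on a saturated ring carbon: an at least 2.8-fold lower number from compound 1 to compound 2 (0.45 log units; beyond the scatter). That step starts from a limit, so its true size is open. The step ends at compound 2 with 17400 nM. It is a single step, and nothing measured yet shows how a butyl group compares with a propyl group. A step of similar size, towards a lower number in this assay, is therefore expected, with a wide margin that reaches close to the limit. The expected step is an at least 3.5-fold lower number from compound 1 to compound 3 (0.55 log units; beyond the scatter). For compound 3 the estimated value is 14000 nM, with an expected range of 4500 nM to 42000 nM.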

Compound 3, concentration for 50% growth inhibition: > 50000 nM
Compound 3 ended at the assay's limit; the forecaster's own chance of this, stated with the estimate: 15%; middle value at least 3.5-fold (0.55 log units) away from the limit.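

In this assay, among these compounds, no step from compound 1 to compound 3 can be read, because both compounds stand at a limit of the assay and not at a number: the limit of > 50000 nM in this assay, at which 2 of the 3 values shown sit.

Left open is the true size of any change from butyl in place of hydrogen on a saturated ring carbon.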